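The source may hold more compounds than are shown below. What is called first, only, known or untested is meant among the compounds shown, and "the series" means these compounds.

Measured in a physicochemical assay for lipophilicity, in phosphate buffer, measured as octanol-water partition, at pH 11.5; a lower number here means a more polar compound, a higher number a more lipophilic compound:
- compound 1 `CCCCOC(=N)NC(=N)Nc1ccc(Cl)cc1`: 3.32
- compound 2 `CCCNC(=N)NC(=N)Nc1ccc(Cl)cc1`: 2.63
- compound 3 `CCOC(=N)NC(=N)Nc1ccc(Cl)cc1`: 2.32

Compound 3, at 2.32, is the lowest of the three. The nearest measured neighbour is compound 2, with a number 0.31 log units lower from compound 2 to compound 3 (beyond the scatter), and the furthest is compound 1, with a number 1.00 log units lower from compound 1 to compound 3 (beyond the scatter). Both steps are beyond the scatter.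

The next step leads to compound 4 `CCCCNC(=N)NC(=N)Nc1ccc(Cl)cc1`, which is not yet measured: butylamino in place of ethoxy on a carbon with a double bond to nitrogen.

Among the measured compounds shown here, two measured steps bear on this change. Read in reverse, the small step of a number 0.31 log units lower from compound 2 to compound 3 (beyond the scatter) puts propylamino above ethoxy. Read in reverse, the larger step of a number 1.00 log units lower from compound 1 to compound 3 (beyond the scatter) puts butoxy above ethoxy, which suggests that a longer chain on this carbon raises the number. The third step, a number 0.69 log units lower from compound 1 to compound 2 (beyond the scatter), changes both chain and linking atom, so it adds little. For the measured compounds named here, no butylamino compound has been measured, and whether the two contributions add up is untested.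

A rise larger than the first step and somewhat smaller than the sum of both is therefore expected in this assay, estimated as a number 0.78 log units higher from compound 3 to compound 4 (beyond the scatter). For compound 4 the expected value is 3.1, with an estimated range from 2.8 to 3.5.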

Compound 4, partition coefficient: 3.13
Compound 4: middle estimate off by 0.03 log units, on the low side, within the range that was stated.
By their numbers in this assay, from the lowest: compound 3; then compound 2; then compounds 4 and 1 (each within the scatter of the next).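

Among the compounds shown here, compound 4 gives the first step in which only the chain changes while the amine nitrogen stays in place on the carbon with a double bond to nitrogen: in this assay, methyl in place of hydrogen on the chain gives a number 0.50 log units higher from compound 2 to compound 4 (beyond the scatter) and so shows that the chain alone moves the number on the nitrogen-linked side. For the compounds shown here, it also gives the first comparison of oxygen and nitrogen links at an equal butyl length, and butylamino in place of butoxy gives a number 0.19 log units lower from compound 1 to compound 4 (within the scatter) so that this change of linking atom cannot be told apart. Going by these compounds alone, the step butylamino in place of ethoxy, a number 0.81 log units higher from compound 3 to compound 4 (beyond the scatter) then fits a simple reading of compounds 1 to 4, in which every step beyond the scatter includes a change in chain length and the one step with the chain length unchanged stays within it.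

An ethylamino compound would test at a short chain whether oxygen and nitrogen links still cannot be told apart, as they cannot at butyl. Whether the rise continues with a longer chain such as hexylamino, or holds for a branched chain such as isobutylamino, remains open, and nothing measured here gives a cause for any of these steps.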